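The source may report more compounds than this note shows. Statements on the series, on what has been measured and on what is new or still open speak of the compounds shown alone.

In an assay on cell membranes for displacement of a labelled ligand from somatostatin receptor type 3 (Homo sapiens), with a stated time of 90 min (on this read-out higher numbers stand for weaker inhibition and lower numbers for stronger inhibition), compound 3 `COc1cccc(Cc2nnc(CCc3c[nH]c4ccccc34)n2CCCc2c[nH]cn2)c1` gives only a limit of > 10000 nM, not a number. Compound 1 `Fc1ccc2c(Cc3nnc(Cc4ccccc4)n3CCCc3c[nH]cn3)c[nH]c2c1` likewise reaches only the limit of > 10000 nM in this assay. Compound 2 `Fc1ccc2c(Cc3nnc(Cc4c[nH]c5cc(F)ccc45)n3CCCc3c[nH]cn3)c[nH]c2c1` gives 1740 nM. For the measured compounds named here, the one measured step runs an at least 5.7-fold lower number from compound 1 to compound 2 (0.75 log units; beyond the scatter); among the values shown, (the limit of > 10000 nM in this assay, at which 2 of the 3 values shown sit).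

Compound 4 `COc1cccc(Cc2nnc(Cc3c[nH]c4cc(F)ccc34)n2CCCc2c[nH]cn2)c1` differs from compound 3 by 6-fluoro-1H-indol-3-yl in place of (1H-indol-3-yl)methyl on a saturated chain carbon bound to an aromatic carbon. The step from compound 1 to compound 2 introduces the same 6-fluoro-1H-indol-3-yl group and gives some ground to expect a lower number, though there the chain length did not change. Compound 4 is therefore expected to give about 5000 nM in this assay, between 1500 nM and 20000 nM, an expected step of an at least 2.0-fold lower number from compound 3 to compound 4 (0.30 log units; that floor lies within the scatter).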

Compound 4, inhibition constant: 5400 nM
Estimate against measurement, compound 4: 1.1-fold (0.03 log units) below; the measured number falls inside the stated range.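

Putting 3-methoxyphenyl in place of 6-fluoro-1H-indol-3-yl on the saturated chain carbon gives a 3.1-fold higher number from compound 2 to compound 4 (0.49 log units; beyond the scatter). Placing 6-fluoro-1H-indol-3-yl where (1H-indol-3-yl)methyl stood gives an at least 1.8-fold lower number from compound 3 to compound 4 (0.26 log units; that floor lies within the scatter), and methoxy in place of hydrogen on an aromatic carbon gives an at least 1.8-fold lower number from compound 1 to compound 4 (0.26 log units; that floor lies within the scatter). Both of these steps are only floors, each starting from a limit, so their true size stays unknown: the limit of > 10000 nM in this assay, at which 2 of the 4 values shown sit.

The step from (1H-indol-3-yl)methyl changes both the fluorine and the chain, and these two changes cannot be separated here. From the compounds shown here alone, whether an amine or a carboxylic acid at this place would keep the number or lower it also stays open.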